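Pyrazole ureas and amides: hydroxy to methoxy step

This account rests on a few compounds, and the source may have more. Where it says the series, first, only, none or still open, it means among the compounds named here.

Measured compounds:
Compound 1 `O=C(Nc1cccc(-n2cc(-c3ccncc3)c(-c3cc(O)cc(Cl)c3)n2)c1)Nc1ccc(Cl)c(Cl)c1`: -38.1%
Compound 2 `COc1cc(Cl)cc(-c2nn(-c3cccc(NC(=O)Nc4ccc(Cl)c(Cl)c4)c3)cc2-c2ccncc2)c1`: -21%
Compound 3 `O=C(Nc1cccc(-n2cc(-c3ccncc3)c(-c3cc(O)cc(Cl)c3)n2)c1)c1cc(C(F)(F)F)cc(C(F)(F)F)c1`: -34.6%

In a functional assay on MDA-MB-231 cells (Homo sapiens) for inhibition, read by sulforhodamine B assay, with a stated time of 48 h, tested at 10 uM (on this read-out higher numbers stand for a weaker effect at the one concentration tested and lower numbers for a stronger effect), compound 1 gives -38.1% and compound 2 gives -21%. The two differ by methyl in place of hydrogen on an oxygen on an aromatic ring, and the step reads a number 17.1 percentage points higher from compound 1 to compound 2 (beyond the scatter). Compound 3 gives -34.6% in this assay; against compound 1 the difference between the two cores is not broken down here, and the two values lie within the scatter of each other, so no order between them is claimed.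

Compound 4 `COc1cc(Cl)cc(-c2nn(-c3cccc(NC(=O)c4cc(C(F)(F)F)cc(C(F)(F)F)c4)c3)cc2-c2ccncc2)c1` has not been measured. It stands to compound 3 as compound 2 stands to compound 1: the difference is methyl in place of hydrogen on an oxygen on an aromatic ring, and the place of the change is the same in both pairs, on an oxygen on an aromatic ring whose other neighbour is an aromatic carbon. The change occurs twice among these four compounds, once measured and once not.

Among the compounds with values here, with only one measured instance to rest on, the expectation for compound 4 is drawn from that instance alone. The step from compound 3 to compound 4 is expected to be a number 15.6 percentage points higher from compound 3 to compound 4 (beyond the scatter), of similar size to the measured step because a number 17.1 percentage points higher from compound 1 to compound 2 (beyond the scatter). On this basis compound 4 is estimated at -19% in this assay, with a range from -36% to -3%, the width reflecting that a single prior step carries its own scatter.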

Compound 4, a percentage reported as activity, at one concentration (the size of the read-out at that concentration, not a potency): 56.7%
Beside the measured number, compound 4's estimate is 75.7 percentage points below it; the measured number lies above the stated range.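

In this assay the hydroxy to methoxy change on the 3-chloro-5-hydroxyphenyl group reads a number 91.3 percentage points higher from compound 3 to compound 4 (beyond the scatter), and its size does not carry over unchanged from one core to the other: the same change on two cores in this assay, a number 17.1 percentage points higher (beyond the scatter) from compound 1 to compound 2 and a number 91.3 percentage points higher (beyond the scatter) from compound 3 to compound 4, 74.2 percentage points apart, beyond the scatter of two such steps

The direction is shared by the two pairs, with the methoxy compound giving the higher number and so the weaker effect in each, but a step measured on the core of compound 1 is a poor guide to the size of the step on the core of compound 3. Two pairs show only that the size of the step depends on the surrounding molecule; they do not show which part of it matters, why the size differs, or how the change would behave on any further core.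

Still open, on these data alone, is whether an ethoxy group or an amine in place of the hydroxy would give a small step or a large one on each core. Also open, as far as these compounds go, is which of the features separating the two cores, the urea or amide link or the aryl group it carries, goes with the larger step; a compound combining the link of one core with the aryl group of the other would separate the two.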